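From Trifluoromethyl to Cyclopropyl on an Aromatic Carbon

A few compounds are considered here, and "the series" means these few. Any claim that something is new, unique, unknown or untested is made for them only; others in the source may bear on it.

In a functional assay (mast cells) for inhibition, with Rattus norvegicus as the target (a higher number here means that more compound is needed for the effect, a lower number that less compound is needed), compound 1 `CC1CC/C(=N\Nc2ccc(C(F)(F)F)cc2)c2ncc(C(=O)O)c(=O)n21` gives 280 nM, and a further entry for it carries no single number. Compound 2 `CC1CCC(=NNc2ccccc2C(=O)O)c2ncc(C(=O)O)c(=O)n21` gives 569000 nM; 1100000 nM (2 entries), so it needs far more compound for the same effect than compound 1 does. The next structure, compound 3 `CC1CC/C(=N\Nc2ccc(C3CC3)cc2)c2ncc(C(=O)O)c(=O)n21`, has cyclopropyl in place of trifluoromethyl on an aromatic carbon, para to a large group: cyclopropyl in place of trifluoromethyl on an aromatic carbon. Going by the values given here, no measured pair differs in just one place, so the data give no direct guide to the size of this change. A small step towards needing more compound is expected in this assay, starting from the 280 nM of compound 1. The expected change is a 2.1-fold higher number from compound 1 to compound 3 (0.33 log units; beyond the scatter). For compound 3 the estimate is 600 nM, with an expected range from 150 nM to 2400 nM.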

Compound 3, half-maximal effective concentration: 1000 nM
Compound 3: middle estimate off by 1.7-fold (0.22 log units), on the low side, and the stated range covers the measured number.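

Going by these compounds alone, replacing trifluoromethyl with cyclopropyl on this aromatic carbon gives the first comparison in this assay that isolates a single change, with a 3.6-fold higher number from compound 1 to compound 3 (0.55 log units; beyond the scatter). The number therefore responds to the group at this position, but only modestly for this swap, and a group of carbon only, with a three-membered ring, still gives a measurable effect. Repeat entries in this assay can lie well apart, so the exact size of this one step calls for some caution: the several entries of compound 2 in this assay, 569000 nM; 1100000 nM (2 entries)

This single swap cannot separate the loss of fluorine from the gain of the ring. As far as these compounds go, how an amine, a methoxy group or a longer alkyl chain on the same aromatic carbon would move the number remains open.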